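The source may report more compounds than this note shows. Statements on the series, on what has been measured and on what is new or still open speak of the compounds shown alone.

Measured so far in an assay for inhibition of 4-hydroxyphenylpyruvate dioxygenase (Sus scrofa), read by spectrophotometry, with a stated time of 15 min; a lower number here means a stronger inhibitor, a higher number a weaker inhibitor:
Compound 1, `O=C1CCCC(=O)C1Cc1ccccc1[N+](=O)[O-]`: compound 1 gives 126000 nM.
Compound 2, `O=C1CCCC(OC(=O)C2CC2)=C1Cl`: compound 2 gives 15 nM.

Of these two numbers compound 2 stands at the lower one, the figure for compound 1 lying far above it; the gap between compound 1 and compound 2 is well beyond the scatter of this assay. Going by the values given here, no single-point step between measured compounds is on record, so the two values show only that compound 2 is by far the stronger inhibitor of the pair.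

Compound 3, `O=C1CCCC(OC(=O)C2CC2)=C1Br`, differs from compound 2 by bromo in place of chloro on a double-bonded ring carbon. The change is a halogen for a halogen on the same carbon, with no ring, no donor and no acceptor added or removed. Among the compounds with values here, nothing among the measured compounds tells how this assay answers such a swap. Compound 3 is therefore expected to lie close to compound 2, with a step of no change at the digits printed from compound 2 to compound 3 (within the scatter) that stays within the scatter. For compound 3 the estimate is 15 nM, in a range from 5 nM to 45 nM.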

Compound 3, half-maximal inhibitory concentration: 28 nM
Compound 3: middle estimate off by 1.9-fold (0.27 log units), on the low side, within the range that was stated.
By their numbers in this assay, from the lowest: compounds 2 and 3 (each within the scatter of the next); then compound 1.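

In this assay, going by these compounds alone, bromo in place of chloro on a double-bonded ring carbon gives a 1.9-fold higher number from compound 2 to compound 3 (0.27 log units; within the scatter) and so supplies the first single-point step on record. At this position, with the rest of the structure held the same, the assay does not separate the two halogens, and compound 2 and compound 3 stand together, far from compound 1. No measurement of any other kind is available to explain this result.

The compounds shown leave open how this ring carbon answers a group other than these two halogens, such as fluoro, methyl, a nitrile or an amine. They also leave open what happens when the group of 6 heavy atoms on the neighbouring ring atom gives way to a longer chain or a carboxylic acid.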